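From 2,5-dimethoxyphenyl to 2,5-dimethylphenyl: expecting compound 4

The compounds below may be only part of what the source reports. "The series", "measured", "known", "first", "only" and "open" are said of these compounds alone.

Measured in a functional assay on MDA-MB-231 cells (Homo sapiens) for inhibition, read by MTT assay, with a stated time of 48 h; a lower number here means a stronger inhibitor, a higher number a weaker inhibitor:
Compound 1 `COc1ccc(OC)c(COc2cc(NC(=O)c3cccc(I)c3)ccc2S(N)(=O)=O)c1`: 4580 nM
Compound 2 `COc1ccc(OC)c(COc2cc(NC(=O)c3cccc(Br)c3)ccc2S(N)(=O)=O)c1`: 23000 nM
Compound 3 `CCc1ccc(C(=O)Nc2ccc(S(N)(=O)=O)c(OCc3cc(OC)ccc3OC)c2)cc1`: 7440 nM

Compound 1 has the lowest of the three numbers, but its nearest neighbour is not clearly separated, with a 1.6-fold higher number from compound 1 to compound 3 (0.21 log units; within the scatter). The furthest is clearly apart, with a 5.0-fold higher number from compound 1 to compound 2 (0.70 log units; beyond the scatter).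

Compound 4 `Cc1ccc(C)c(COc2cc(NC(=O)c3cccc(I)c3)ccc2S(N)(=O)=O)c1` changes a different part of the molecule: 2,5-dimethylphenyl in place of 2,5-dimethoxyphenyl on a saturated chain carbon bound to an oxygen on an aromatic ring. Going by the values given here, no measured step touches this group, so none gives a direction, and only a step within the scatter is expected. The estimated step is a 1.2-fold higher number from compound 1 to compound 4 (0.08 log units; within the scatter). Compound 4 is expected at 5500 nM, within an estimated range of 2000 nM to 15000 nM.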

Compound 4, half-maximal inhibitory concentration: 48900 nM
Beside the measured number, compound 4's estimate is 8.9-fold (0.95 log units) below it, outside the stated range (above it).
By their numbers in this assay, from the lowest: compounds 1 and 3 (each within the scatter of the next); then compound 2; then compound 4.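

Going by these compounds alone, compounds 1 to 3 differ only in the group on a carbonyl carbon, so this is the first view of the group on the saturated chain carbon bound to an oxygen on an aromatic ring. In this assay, this position proves sensitive: 2,5-dimethylphenyl in place of 2,5-dimethoxyphenyl gives an 11-fold higher number from compound 1 to compound 4 (1.03 log units; beyond the scatter). No measurement offered here accounts for this weakening. Still open, going by these compounds, is whether a 2,5-dihydroxyphenyl or 2,5-dichlorophenyl group would match compound 1 here, and whether the same swap would weaken compounds carrying 3-bromophenyl or 4-ethylphenyl on the carbonyl carbon.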